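The compounds below may be only part of what the source reports. "The series", "measured", "known", "first", "only" and "open" are said of these compounds alone.

The study compares simple benzylamines that carry two aromatic rings joined through a short chain. For the measured compounds named here, compound 1 `Oc1ccccc1CCCNCc1ccccc1O` is the only one with a number: in an assay on isolated protein for inhibition of Myeloperoxidase (Homo sapiens), with a stated time of 5 min, in the presence of a further agent that is not named here (a lower number here means a stronger inhibitor, a higher number a weaker inhibitor), compound 1 gives 350 nM. For compound 2 `COc1ccccc1CCCNCc1ccccc1F` the entry in this assay reads no result reported, so nothing can be said of where it sits. Compound 3 `Oc1ccccc1CCCNCc1ccccc1F` differs from compound 2 by one change: hydrogen in place of methyl on an oxygen on an aromatic ring. Going by the values given here, since no measured pair of this kind exists here, the size of the step from compound 2 to compound 3 in this assay can only be guessed; a shift toward a lower number, beyond the usual scatter, is expected. Compound 3 is expected to give about 1000 nM, within a range from 200 nM to 5000 nM.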

Compound 3, half-maximal inhibitory concentration: 270 nM
Estimate against measurement, compound 3: 3.7-fold (0.57 log units) above; low and high end bracket the measured number.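

In this assay, putting fluoro in place of hydroxy on an aromatic carbon gives a 1.3-fold lower number from compound 1 to compound 3 (0.11 log units; within the scatter), so at this place in the shared core the two groups cannot be told apart by this measurement. Nothing shown here gives a reason for this match. Going by these compounds, the step from compound 2 to compound 3 cannot be read, so the effect of methoxy to hydroxy remains unknown. On these data alone, whether a chlorine atom or an amine at the fluoro position would fit as well stays open, as does the effect of a longer chain between the rings.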